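This account rests on a few compounds, and the source may have more. Where it says the series, first, only, none or still open, it means among the compounds named here.

Measured in a functional assay on SEM cells (Homo sapiens) for cytotoxicity, with a stated time of 72 h; a higher number here means that more compound is needed for the effect, a lower number that less compound is needed:
- Compound 1 `C=C[C@@](C)(/C=C/c1ccc(O)cc1)CCC1OC1(C)C`: > 36600 nM
- Compound 2 `C=C[C@@](C)(/C=C/c1ccc(O)cc1)CC/C=C/C(=O)OCc1ccccc1`: > 36600 nM

Compound 1 gives no exact number: its > 36600 nM is a limit of the assay. The two measured compounds share one reading, (the limit of > 36600 nM in this assay, at which 2 of the 2 values shown sit), so neither can be ranked against the other.

Compound 3 `C=C[C@@](C)(/C=C/c1ccc(O)cc1)CC/C=C(\C)C=O` has not yet been measured. It carries 2-formylprop-1-en-1-yl in place of 3,3-dimethyloxiran-2-yl on a saturated chain carbon, three bonds along the chain from two double-bonded chain carbons.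

Among the measured compounds shown here, no measured step shows what such a change does. Compound 2, with a different chain end again, also gives only the limit > 36600 nM. A small shift towards lower numbers is therefore the most that seems likely, and another limit reading is quite possible. The expected change is an at least 1.2-fold lower number from compound 1 to compound 3 (0.08 log units; that floor lies within the scatter). For compound 3 the estimated value is 30000 nM, with an expected range from 12000 nM to 60000 nM.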

Compound 3, half-maximal effective concentration: > 36600 nM
Compound 3 gave a limit, no number; the forecaster's own chance of this, stated with the estimate: 60%; at least 1.2-fold (0.08 log units) between middle value and limit.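

Compound 3 gives > 36600 nM in this assay, which is a limit and not a number. No step from compound 1 to compound 3 can be read, as all three compounds share one reading: the limit of > 36600 nM in this assay, at which 3 of the 3 values shown sit.

The compounds shown leave open whether any change at this chain end lowers the concentration needed for the effect.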